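The compounds below may be only part of what the source reports. "The series", "measured", "known", "first", "only" and "open" are said of these compounds alone.

Of the compounds shown here, three have so far been measured in a functional assay on the whole organism with Rattus norvegicus as the target, with a stated time of 4 h, at a dose of 40 mg/kg by the intraperitoneal route; a lower number here means less inhibition, a higher number more inhibition at the dose given (going by the name of the read-out). Compound 1 `Cc1nc2c(COc3ccccc3)cccn2c1C` gives 48%, compound 2 `Cc1nc2c(CSc3ccccc3)cccn2c1C` gives 29%, and compound 3 `Cc1nc2c(OCc3ccccc3)cccn2c1C(N)=O` gives 42%. Among these three numbers compound 3 stands second highest. Its nearest neighbour is compound 1, whose number lies within the usual scatter of that of compound 3, so the two cannot be told apart. Its furthest neighbour is compound 2, whose number lies beyond the scatter, so compound 3 shows more inhibition than compound 2.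

The account now turns to compound 4 `COCc1c(C)nc2c(OCc3ccccc3)cccn12`, which has not yet been measured in this assay. It differs from compound 3 in one place: methoxymethyl in place of carbamoyl on an aromatic carbon. The group that leaves carries a hydrogen-bond donor, the group that enters carries none. Among the compounds with values here, no measured pair in this set shows a change of this kind, so there is no step from which its size could be read directly. Given that compound 3 gives 42%, the expected step of a number 2 percentage points lower from compound 3 to compound 4 (within the scatter) is small and is not expected to go beyond the scatter in either direction. Compound 4 is accordingly estimated to give 40% in this assay, with a range from 20% to 60%.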

Compound 4, a percentage reported as inhibition, in the whole organism at one dose (the size of the read-out at that dose, not a potency): 99%
Compound 4: middle estimate off by 59 percentage points, on the low side; the measured number lies above the stated range.
By their numbers in this assay, from the lowest: compound 2; then compounds 3 and 1 (each within the scatter of the next); then compound 4.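

In this assay, methoxymethyl in place of carbamoyl on this aromatic carbon brings a number 57 percentage points higher from compound 3 to compound 4 (beyond the scatter), which shows that the read-out at the dose given depends strongly on the group at this position of the five-membered aromatic ring. The hydrogen-bond donor of carbamoyl is therefore not needed on this carbon for high inhibition, at least in this pair, where the number rises rather than falls once the donor has left. Nothing in the available data bears on why this single change has so large an effect.

Whether the rise belongs to methoxymethyl itself or simply follows the loss of carbamoyl stays open, as the compounds shown include no ethoxymethyl, aminomethyl or carboxylic acid on this carbon with the rest of compound 4 unchanged. On these data alone, it also remains open how compound 3 and compound 4 would compare at lower doses, as a reading at one dose gives the size of the effect at that dose and not a potency.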